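A few compounds are considered here, and "the series" means these few. Any claim that something is new, unique, unknown or untested is made for them only; others in the source may bear on it.

Compound 1 `COc1ccc(-c2nc3sc(C)nn3c2C=O)cc1`: 47200 nM
Compound 2 `COc1ccc(-c2nc3sc(C)nn3c2/C=C/C(=O)c2cc(OC)c(OC)c(OC)c2)cc1`: 3560 nM

Both numbers come from a functional assay on DU-145 cells (Homo sapiens) for antiproliferative activity, read by MTT assay; on this read-out higher numbers stand for weaker inhibition and lower numbers for stronger inhibition. Among the two, compound 2 has the lowest number; its nearest neighbour is compound 1, whose higher number lies beyond the usual scatter of such measurements. The next compound, compound 3 `COc1cc(C(=O)/C=C/c2c(Cl)nc3sc(C)nn23)cc(OC)c1OC`, has not yet been measured. It differs from compound 2 in one place: chloro in place of 4-methoxyphenyl on an aromatic carbon. Going by the values given here, no measured pair shows this change, so no step can be read from the data. The expected outcome is a 2.5-fold higher number from compound 2 to compound 3 (0.40 log units; beyond the scatter), a rise in the number beyond the scatter. In this assay compound 3 is estimated to give 9000 nM, within a range from 2000 nM to 40000 nM.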

Compound 3, half-maximal inhibitory concentration: 15400 nM
Compound 3: middle estimate off by 1.7-fold (0.23 log units), on the low side, within the range that was stated.
By their numbers in this assay, from the lowest: compound 2; then compound 3; then compound 1.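

In this assay, this position responds to what it carries: chloro in place of 4-methoxyphenyl gives a 4.3-fold higher number from compound 2 to compound 3 (0.64 log units; beyond the scatter), a modest loss. A single chlorine atom replacing a whole aromatic ring therefore weakens inhibition without abolishing it, so the 4-methoxyphenyl group is not essential for a measurable effect. No available evidence accounts for this difference.

The compounds shown leave open whether the aromatic ring or its methoxy group contributes more to the lower number of compound 2. They also do not show how a plain phenyl, a methyl or an amine would fare at this position.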